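The compounds below may be only part of what the source reports. "The series", "measured", "known", "first", "only" and "open" are said of these compounds alone.

Among the measured compounds shown here, compound 1, `CC(C)[C@H](NC(=O)COc1cccc2ccccc12)C(=O)N[C@@H](CC(=O)O)C(=O)COc1ccc(-c2ccccc2)cc1`, gives 38700 nM in a functional assay with Homo sapiens as the target; on this read-out higher numbers stand for weaker inhibition and lower numbers for stronger inhibition; of the two numbers measured so far it is the highest. For the measured compounds named here, compound 2, `CC(C)[C@H](NC(=O)COc1cccc2ccccc12)C(=O)N[C@@H](CC(=O)O)C(=O)COc1c(F)c(F)c(F)c(F)c1F`, gives 8890 nM in this assay, and the single change between them is a 4.4-fold lower number from compound 1 to compound 2 (0.64 log units; beyond the scatter). Compound 3, `CC(C)[C@H](NC(=O)COc1cccc2ccccc12)C(=O)N[C@@H](CC(=O)O)C(=O)COc1cccc(C(F)(F)F)c1F`, has not yet been measured; it differs from compound 1 in one place: 2-fluoro-3-(trifluoromethyl)phenyl in place of 4-phenylphenyl on an oxygen on a saturated carbon. Going by the values given here, the only measured step that bears on this change is the one from compound 1 to compound 2, where a fluorinated single ring likewise took the place of the 4-phenylphenyl group and gave a modest lowering beyond the scatter. A lowering of similar or somewhat smaller size is therefore expected here, as a 2.6-fold lower number from compound 1 to compound 3 (0.41 log units; beyond the scatter). Compound 3 is accordingly estimated to give 15000 nM in this assay, with a likely range from 5000 nM to 40000 nM.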

Compound 3, half-maximal inhibitory concentration: 18200 nM
Beside the measured number, compound 3's estimate is 1.2-fold (0.08 log units) below it; measured number inside the range.
By their numbers in this assay, from the lowest: compound 2; then compound 3; then compound 1.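

In this assay, putting 2-fluoro-3-(trifluoromethyl)phenyl in place of 4-phenylphenyl on the oxygen gives a 2.1-fold lower number from compound 1 to compound 3 (0.33 log units; beyond the scatter) and so shows that the lowering at this place is not confined to the 2,3,4,5,6-pentafluorophenyl group. The two fluorinated single rings do not match each other, though, since exchanging one for the other gives a 2.0-fold higher number from compound 2 to compound 3 (0.31 log units; beyond the scatter) and leaves the pentafluorinated ring with the lowest number of the three. Nothing measured here accounts for these differences.

These compounds change the number of rings and add fluorine together, so they leave open which of the two goes with the lower numbers. A plain phenyl group, with one ring and no fluorine, would separate them, and a ring carrying an amine would test a quite different kind of substituent.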